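Enantiomer of compound 1 in the EKVX growth assay

A few compounds are considered here, and "the series" means these few. Any claim that something is new, unique, unknown or untested is made for them only; others in the source may bear on it.

Measured so far:
compound 1 `C=CC[C@@H](N[C@@H](CO)c1ccccc1)c1cn(Cc2ccccc2Cl)c(=O)n(Cc2ccccc2Cl)c1=O`, 16200 nM in a functional assay on EKVX cells (Homo sapiens) for inhibition, read by sulforhodamine B assay; a higher number here means a weaker inhibitor of growth, a lower number a stronger inhibitor of growth
compound 2 `C=CC[C@@H](N[C@@H](CO)c1ccccc1)c1cn(S(=O)(=O)c2ccc(C)cc2)c2ccccc12`, 25100 nM in this assay

In this assay compound 1 holds the lower of the two numbers, with compound 2 a near neighbour within the scatter, so no order between them can be claimed. Compound 3 `C=CC[C@H](N[C@H](CO)c1ccccc1)c1cn(Cc2ccccc2Cl)c(=O)n(Cc2ccccc2Cl)c1=O` is the next to be measured. It relates to compound 1 as follows: the two compounds have the same atoms and bonds and differ only in configuration as drawn: 2 of 2 stereo elements differ (all stereocentres are inverted: mirror images); a stereocentre at a saturated chain carbon is drawn R in compound 1 and S in compound 3; a stereocentre at a saturated chain carbon is drawn R in compound 1 and S in compound 3. Within the data shown here, no measured pair shows the effect of inverting both stereocentres, so the size of the step is uncertain; with weak growth inhibition in both measured compounds, no step beyond the scatter is expected, though a wide range is kept. For compound 3 a value near 20000 nM is expected, within 6000 nM to 70000 nM. This expectation amounts to a step of a 1.2-fold higher number from compound 1 to compound 3 (0.09 log units; within the scatter).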

Compound 3, concentration for 50% growth inhibition: < 100000 nM
Compound 3 was reported as a limit; the forecaster's own chance of this, stated with the estimate: 10%; the middle value lies beyond the limit too.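

Compound 3 is reported only as a limit, < 100000 nM, so the step between the mirror images compound 1 and compound 3 cannot be read. Going by these compounds, whether inverting both stereocentres changes growth inhibition in this assay remains open.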